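Halogen variation on the benzyl ring of compound 3

The source may report more compounds than this note shows. Statements on the series, on what has been measured and on what is new or still open speak of the compounds shown alone.

In a functional assay on the whole organism for activation, with Mus musculus as the target (a lower number here means that less compound is needed, a higher number that more compound is needed for the effect), compound 3 `Nc1ncnc2c1nc(O)n2Cc1ccccc1` gives 30 mg/kg. Compound 1 `Nc1ncnc2c1nc(O)n2Cc1ccc(Cl)cc1` gives 30 mg/kg; the two stand level at the digits shown and together hold the highest numbers of the three, with no change at the digits printed from compound 1 to compound 3 (within the scatter). Compound 2 `CCCCCOc1nc(N)c2nc(O)n(Cc3ccccc3)c2n1` gives 0.3 mg/kg, and a 100-fold higher number from compound 2 to compound 3 (2.00 log units; beyond the scatter). Compound 4 `Nc1ncnc2c1nc(O)n2Cc1ccc(F)cc1` differs from compound 3 by fluoro in place of hydrogen on an aromatic carbon. The step that bears on this change is no change at the digits printed from compound 1 to compound 3 (within the scatter), where chloro at the place fluoro now enters left the number unchanged; a 100-fold higher number from compound 2 to compound 3 (2.00 log units; beyond the scatter) concerns another place and does not bear on it. A step of about no change at the digits printed from compound 3 to compound 4 (within the scatter) is therefore expected, nothing beyond the scatter. Compound 4 is estimated at 30 mg/kg, with a range from 10 mg/kg to 100 mg/kg.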

Compound 4, minimum effective dose: 30 mg/kg
The estimate for compound 4 equals the measured number at the digits printed, and the stated range covers the measured number.
By their numbers in this assay, from the lowest: compound 2; then compounds 1, 3 and 4 (each within the scatter of the next).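

Fluoro, para to a large group on the aromatic ring of carbon only, gives no change at the digits printed from compound 3 to compound 4 (within the scatter) in this assay and extends the earlier chloro result at this place to a second halogen. Exchanging the two halogens gives no change at the digits printed from compound 1 to compound 4 (within the scatter) as well, so hydrogen, fluoro and chloro cannot be told apart here. No evidence on hand explains this flat response.

From the compounds shown here alone, whether a methoxy group, an amine or a carboxylic acid at this place would shift the number stays open. Also open, going by these compounds, is whether fluoro or chloro would stay without effect alongside the pentyloxy group of compound 2.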